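The source may hold more compounds than are shown below. What is called first, only, known or untested is meant among the compounds shown, and "the series" means these compounds.

The study turns on a shared core varied at a saturated chain carbon bound to an aromatic nitrogen. Compound 1 `NC(=O)c1cn(Cc2ccccc2)c2ncnc(N)c12` carries a phenyl on that carbon, and in a functional assay on KB cells (Homo sapiens) for cytotoxicity (on this read-out higher numbers stand for weaker inhibition and lower numbers for stronger inhibition), compound 1 gives 75000 nM. Compound 2 `CCCn1cc(C(N)=O)c2c(N)ncnc21` has ethyl in place of phenyl there; in this assay compound 2 gives 100000 nM, so that a 1.3-fold higher number from compound 1 to compound 2 (0.12 log units; within the scatter). Compound 3 `Cn1cc(C(N)=O)c2c(N)ncnc21` has hydrogen in place of phenyl, and in this assay compound 3 reaches only a limit of the assay, > 100000 nM. Of the three measured values, then, the two plain numbers sit close together, and the third is the limit of > 100000 nM in this assay, at which 1 of the 3 values shown sits; in this assay an at least 1.3-fold higher number from compound 1 to compound 3 (0.12 log units; that floor lies within the scatter), while a number no lower from compound 2 to compound 3 (the limit leaves the size open).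

Compound 4 `CC(C)(C)c1ccc(Cn2cc(C(N)=O)c3c(N)ncnc32)cc1` keeps the phenyl of compound 1 and differs from it by tert-butyl in place of hydrogen on an aromatic carbon. Among the compounds with values here, none of the measured steps touches this aromatic carbon; all of them exchange the group on the saturated chain carbon, and those with readable sizes stay within the scatter. They show the read-out in this assay barely moving across these variations, so no step beyond the scatter is expected in either direction. Compound 4 is therefore expected to give, in this assay, a number near that of its parent: 60000 nM, with a range from 20000 nM to 100000 nM. This estimate amounts to an expected 1.3-fold lower number from compound 1 to compound 4 (0.10 log units; within the scatter).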

Compound 4, half-maximal inhibitory concentration: 900 nM
The estimate for compound 4 lay 67-fold (1.82 log units) above the measured number; the whole stated range lies above it.
By their numbers in this assay, from the lowest: compound 4; then compounds 1 and 2 (each within the scatter of the next).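

On the six-membered aromatic ring of compound 1, the read-out in this assay proves highly sensitive to change: with tert-butyl in place of hydrogen there is an 83-fold lower number from compound 1 to compound 4 (1.92 log units; beyond the scatter), a step beyond the scatter. The earlier steps shown here, all at the saturated chain carbon, gave nothing of this kind: those with a readable size stayed within the scatter, and the step from compound 2 to compound 3 cannot be read. The phenyl, which alone gave no step beyond the scatter against ethyl, thus emerges as a carrier for a group that lowers the number sharply, though nothing shown gives a measured reason for this step.

On these data alone, it remains open whether a methyl, a chlorine, an amine or a carboxylic acid on the same aromatic carbon would lower the number as tert-butyl does, or whether the size of the step follows the size of the entering group. As far as these compounds go, it also remains open whether tert-butyl would have the same result on another carbon of that ring, or on a longer chain in place of the phenyl.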